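The compounds below may be only part of what the source reports. "The series", "measured", "known", "first", "only" and "open" are said of these compounds alone.

Working notes on the series. Compound 1 `CCn1c(=O)c2nc(-c3ccc(S(=O)(=O)N4CCSCC4)cc3)[nH]c2n(CC)c1=O` and compound 2 `CCn1c(=O)c2nc(-c3ccc(S(=O)(=O)NCC(C)O)cc3)[nH]c2n(CC)c1=O` share the same core and differ only at the sulfonyl sulfur. In an assay for binding affinity to adenosine receptor A1 (Bos taurus) (a lower number here means a stronger inhibitor, a higher number a weaker inhibitor), compound 1 gives 36.6 nM, while in this assay compound 2 gives 4.2 nM; the step of an 8.7-fold lower number from compound 1 to compound 2 (0.94 log units; beyond the scatter) is the only one measured so far, and compound 2 holds the lowest number of the two. Compound 3 `CCn1c(=O)c2nc(-c3ccc(S(=O)(=O)O)cc3)[nH]c2n(CC)c1=O` is not yet measured; it differs from compound 2 by hydroxy in place of (2-hydroxypropyl)amino on a sulfonyl sulfur. Among the compounds with values here, no measured step covers this kind of change: the single step known, from a cyclic amine to an open hydroxyalkylamine on that sulfur, runs toward lower numbers, but it does not tell what removing the amine altogether does. In the absence of a matching precedent, compound 3 is expected to give a higher number than compound 2, with the estimated step being a 71-fold higher number from compound 2 to compound 3 (1.85 log units; beyond the scatter). The estimate for compound 3 in this assay is therefore 300 nM, in a range from 60 nM to 1500 nM, and this expectation carries wide uncertainty.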

Compound 3, half-maximal inhibitory concentration: 755 nM
Compound 3: middle estimate off by 2.5-fold (0.40 log units), on the low side, and the stated range covers the measured number.
By their numbers in this assay, from the lowest: compound 2; then compound 1; then compound 3.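

In this assay, the group on the sulfonyl sulfur now proves able to move the number much further than the change between the two amines showed: hydroxy in place of (2-hydroxypropyl)amino gives a 180-fold higher number from compound 2 to compound 3 (2.25 log units; beyond the scatter) on the shared core. Hydroxy in place of thiomorpholin-4-yl gives a 21-fold higher number from compound 1 to compound 3 (1.31 log units; beyond the scatter) in the same direction, so both the open and the cyclic amine give lower numbers than hydroxy on this sulfur. No supporting data explain the size of either step.

The three compounds leave open whether the rise follows from losing the nitrogen or from losing the carbon chain attached to it. A plain amino or methylamino group on the same sulfur, or a carboxylic acid in place of the sulfo group, would help separate these two readings.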